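Azetidine to dimethylamino on the fused core

The source may report more compounds than this note shows. Statements on the series, on what has been measured and on what is new or still open speak of the compounds shown alone.

Three compounds of the series have numbers in a functional assay on HEK293 cells for antagonist activity at transient receptor potential cation channel subfamily V member 1 (Homo sapiens), read by calcium flux; a lower number here means a stronger inhibitor, a higher number a weaker inhibitor. Compound 1 `FC(F)(F)c1ccc(Nc2ncnc3sc(Nc4ccccc4C(F)(F)F)nc23)cc1` gives 74 nM in this assay. Compound 3 `FC(F)(F)c1ccc(Nc2nc(N3CCC3)nc3sc(Nc4c(Cl)cccc4Cl)nc23)cc1` gives 59 nM in this assay; its number stands lowest of the two shown, but compound 1 sits within the scatter of it, so the two are not distinguished. For compound 2 `O=C(c1ccc(Nc2ncnc3sc(Nc4c(Cl)cccc4Cl)nc23)cc1)N1CCCC1` this assay reports only a limit, > 5000 nM, and no number (the limit of > 5000 nM in this assay, at which 1 of the 3 values shown sits).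

Compound 4 `CN(C)c1nc(Nc2ccc(C(F)(F)F)cc2)c2nc(Nc3c(Cl)cccc3Cl)sc2n1` has not been measured. It differs from compound 3 in one place: dimethylamino in place of azetidin-1-yl on an aromatic carbon. Among the compounds with values here, no measured pair shows what this exchange does, and the groups that leave and enter are of similar kind and size as counted above. The step is therefore expected to stay within the scatter, with no direction to favour, as a 1.2-fold higher number from compound 3 to compound 4 (0.07 log units; within the scatter). Compound 4 is estimated at 70 nM in this assay, with a range from 25 nM to 200 nM.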

Compound 4, half-maximal inhibitory concentration: 59 nM
The estimate for compound 4 lay 1.2-fold (0.07 log units) above the measured number; the range from low to high includes it.
By their numbers in this assay, from the lowest: compounds 3, 4 and 1 (each within the scatter of the next). At a limit, above all of these: compound 2.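

In this assay, within the data shown here, the exchange gives no change at the digits printed from compound 3 to compound 4 (within the scatter) at the aromatic carbon between two ring nitrogen atoms, and this is the first pair that isolates a change at this position. With the rest of the molecule held fixed, the four-membered ring of azetidin-1-yl is not required to keep the number, and dimethylamino, with no ring and 3 heavy atoms in place of 4, serves alike here. Nothing shown explains why the two groups read the same.

Going by these compounds, whether morpholine, piperazine, diethylamino or methylamino on this carbon would keep the number remains open. On these data alone, whether any group is needed here also remains open: compound 1 carries only hydrogen on this carbon but differs in a second place as well, so it gives no single-change comparison.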